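Removing the methyl from the 3-methylpyridin-2-yl group

The source may report more compounds than this note shows. Statements on the series, on what has been measured and on what is new or still open speak of the compounds shown alone.

Compound 1 `Cc1cccnc1-c1ccc(C(=O)Nc2ccc(F)cc2)cc1` gives > 4000 nM in a functional assay for antagonist activity at transient receptor potential cation channel subfamily V member 1 (Rattus norvegicus) (a higher number here means a weaker inhibitor, a lower number a stronger inhibitor), and that value is a limit of the assay rather than a number. Compound 2 `Cc1cccnc1-c1ccc(C(=O)Nc2ccc(C(C)(C)C)cc2)cc1` gives 9 nM in this assay. The step of an at least 440-fold lower number from compound 1 to compound 2 (2.64 log units; beyond the scatter) is large; at its starting point stands (the limit of > 4000 nM in this assay, at which 1 of the 2 values shown sits). Among the compounds with values here, compound 2 therefore holds the only number among the values shown; the other value is a limit.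

Compound 3 `CC(C)(C)c1ccc(NC(=O)c2ccc(-c3ccccn3)cc2)cc1` differs from compound 2 by hydrogen in place of methyl on an aromatic carbon, ortho to a large group and two atoms from the ring nitrogen; cut one bond further out, 3-methylpyridin-2-yl becomes pyridin-2-yl. Within the data shown here, the single measured step concerns the tert-butyl on the other aromatic ring, not this position, so no measured step bears on the change. The expected step is a 1.7-fold higher number from compound 2 to compound 3 (0.22 log units; within the scatter), within the scatter in either direction. Compound 3 is estimated at 15 nM, with a range of 4 nM to 60 nM.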

Compound 3, half-maximal inhibitory concentration: 8 nM
Beside the measured number, compound 3's estimate is 1.9-fold (0.27 log units) above it; low and high end bracket the measured number.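

In this assay, going from 3-methylpyridin-2-yl to pyridin-2-yl gives a 1.1-fold lower number from compound 2 to compound 3 (0.05 log units; within the scatter). With the tert-butyl in place, the methyl on this aromatic carbon, ortho to a large group and two atoms from the ring nitrogen, is therefore not needed for the activity seen in compound 2, whereas the earlier step spoke only to the other aromatic ring. No measurement shown offers a cause for this outcome.

On these data alone, what a chloro, a methoxy or an amine on this same aromatic carbon would do remains open. Within the data shown here, also open is whether the methyl stays as silent with fluoro in place of tert-butyl, since the only fluoro compound, compound 1, carries the methyl and gives a limit rather than a number.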